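Extending the Alkyl Chain of Compound 3

This account rests on a few compounds, and the source may have more. Where it says the series, first, only, none or still open, it means among the compounds named here.

Measured compounds:
compound 1, `CCCCCCCCCCCCCCCCCCNC(=O)[C@@H](N)[C@@H](C)O`, 21400 nM
compound 2, `CCCCCCCCNC(=O)[C@@H](NC(=O)c1ccccc1)[C@@H](C)O`, 200000 nM
compound 3, `CCCCCCCCCCCCCCNC(=O)[C@@H](NC(=O)c1ccccc1)[C@@H](C)O`, 200000 nM

In a functional assay on SW-620 cells (Homo sapiens) for cytotoxicity, read by MTT assay, with a stated time of 48 h (on this read-out lower numbers stand for stronger inhibition and higher numbers for weaker inhibition), compound 3 stands level with compound 2, the two together giving the highest numbers of the three. Compound 1, which carries a free amine in place of the benzamide, gives 21400 nM, a lower number that lies beyond the scatter from compound 3. Compound 4, `CCCCCCCCCCCCCCCCCCNC(=O)[C@@H](NC(=O)c1ccccc1)[C@@H](C)O`, has not been measured. It differs from compound 3 in one place: butyl in place of hydrogen on a saturated chain carbon, ten or more bonds along the chain from an amide-type nitrogen. Among the measured compounds shown here, the only measured step that bears on this kind of change is the one from compound 2 to compound 3, where a similar lengthening of the chain gave no change at the digits printed from compound 2 to compound 3 (within the scatter). On that basis the further lengthening is expected to produce no change at the digits printed from compound 3 to compound 4 (within the scatter), that is, no step beyond the scatter in either direction. Compound 4 is therefore estimated at 200000 nM, with a range from 80000 nM to 400000 nM.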

Compound 4, half-maximal inhibitory concentration: 200000 nM
Estimate against measurement, compound 4: no gap at the digits printed, within the range that was stated.
By their numbers in this assay, from the lowest: compound 1; then compounds 2, 3 and 4 (each within the scatter of the next).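

In this assay, butyl in place of hydrogen on a saturated chain carbon, ten or more bonds along the chain from an amide-type nitrogen, gives no change at the digits printed from compound 3 to compound 4 (within the scatter), and the larger decyl change gives no change at the digits printed from compound 2 to compound 4 (within the scatter), so the flat result now extends across all three benzoyl compounds. Among the compounds shown here, compound 4 also gives the first single-place view of the amine nitrogen: benzoyl in place of hydrogen gives a 9.3-fold higher number from compound 1 to compound 4 (0.97 log units; beyond the scatter), whereas the earlier compounds differed from compound 1 in more than one place. No measurement shown accounts for either result.

From the compounds shown here alone, it remains open whether acetyl on that nitrogen would give a number closer to that of compound 1 or that of compound 4. Also open, going by these compounds, is how the free amine would respond to a shorter chain.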